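From a Dienyl Chain End to Octyl in Compound 3

A few compounds are considered here, and "the series" means these few. Any claim that something is new, unique, unknown or untested is made for them only; others in the source may bear on it.

In a functional assay on MCF7 cells (Homo sapiens) for antiproliferative activity, read by MTT assay (a lower number here means a stronger inhibitor, a higher number a weaker inhibitor), compound 1 (`CCCCCCCCCCCCCCCC1(O)CC(=O)c2c(O)cc(O)cc2O1`) gives 17500 nM as its measured value. In this assay compound 2 (`CCCCC/C=C\C/C=C\CCCCCCCc1cc(=O)c2c(O)cc(O)c(C)c2o1`) gives 17500 nM and so stands level with compound 1, within the usual scatter of repeated measurements.

Compound 3 (`CCCCCCCCCCCCCCCc1cc(=O)c2c(O)cc(O)c(C)c2o1`) differs from compound 2 in one place: octyl in place of deca-1,4-dien-1-yl on a saturated chain carbon, seven bonds along the chain from an aromatic carbon. Within the data shown here, no measured pair isolates this change, so the data give no direct size for it.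

The only indirect hint is weak. Compound 1 also carries a saturated chain, on a different core, and its 17500 nM does not separate from the value of compound 2. A step beyond the scatter in this assay is therefore not expected, and no direction is favoured. The estimated change is a 1.1-fold higher number from compound 2 to compound 3 (0.04 log units; within the scatter) and is expected to stay within the scatter. For compound 3 the estimated value is 19000 nM (expected range 8000 nM to 45000 nM).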

Compound 3, half-maximal inhibitory concentration: 17500 nM
The estimate for compound 3 lay 1.1-fold (0.04 log units) above the measured number, within the range that was stated.
By their numbers in this assay, from the lowest: compounds 1, 2 and 3 (each within the scatter of the next).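

In this assay, among these compounds, octyl in place of deca-1,4-dien-1-yl on a saturated chain carbon, seven bonds along the chain from an aromatic carbon, gives no change at the digits printed from compound 2 to compound 3 (within the scatter), and this is the first direct reading at this position. The step removes both double bonds outside aromatic rings and shortens the group from 10 heavy atoms to 8, yet the read-out does not separate the two chain ends, so in this one pair neither the double bonds nor that difference in length registers beyond the scatter. No measurement is available that would explain why the two chains read alike.

This single pair compares two all-carbon chain ends on one core, so it cannot say how far the position tolerates change in general. As far as these compounds go, it remains open whether a much shorter chain, or an amine or a carboxylic acid at the chain end, would stand apart from compound 2 and compound 3 in this assay.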